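Bromo to Methoxy Again: Expecting Compound 4

This account rests on a few compounds, and the source may have more. Where it says the series, first, only, none or still open, it means among the compounds named here.

Measured so far in a functional assay on K562 cells (Homo sapiens) for cytotoxicity, read by trypan blue exclusion, with a stated time of 96 h; on this read-out lower numbers stand for stronger inhibition and higher numbers for weaker inhibition:
Compound 1, `COc1cc(OC)c(/C=C/S(=O)(=O)Cc2ccc(OC)c([N+](=O)[O-])c2)c(OC)c1`, gives 2500 nM.
Compound 2, `COc1cc(OC)c(/C=C/S(=O)(=O)Cc2ccc(Br)c([N+](=O)[O-])c2)c(OC)c1`, gives 25000 nM.
Compound 3, `COc1cc(OC)c(/C=C/S(=O)(=O)Cc2ccc(OC)c(NC(C(=O)O)c3ccc(Br)cc3)c2)c(OC)c1`, gives 200 nM.

Compound 2 and compound 1 differ in a single place: methoxy in place of bromo on an aromatic carbon. That change brought a 10-fold lower number from compound 2 to compound 1 (1.00 log units; beyond the scatter). Compound 1 and compound 3 also differ in one place, ((4-bromophenyl)(carboxy)methyl)amino in place of nitro on an aromatic carbon, and this brought a 13-fold lower number from compound 1 to compound 3 (1.10 log units; beyond the scatter), leaving compound 3 with the lowest number of the three.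

Compound 4, `COc1ccc(C(Nc2cc(CS(=O)(=O)/C=C/c3c(OC)cc(OC)cc3OC)ccc2OC)C(=O)O)cc1`, has not yet been measured in this assay. It differs from compound 3 by methoxy in place of bromo on an aromatic carbon. Among the compounds with values here, this is the same kind of change as the one from compound 2 to compound 1, but not the same: in the earlier pair the site was also ortho to a nitro group (3 heavy atoms), whereas here it is only para to a large group. The difference between the core of compound 3 and the core of compound 2 is not broken down here.

A smaller step is expected for compound 4, about a 2.0-fold lower number from compound 3 to compound 4 (0.30 log units; within the scatter), because the earlier step of a 10-fold lower number from compound 2 to compound 1 (1.00 log units; beyond the scatter) was measured at a site that also sat ortho to a nitro group (3 heavy atoms) and on a part of the molecule compound 4 does not share. Compound 4 is therefore estimated to give 100 nM, most likely between 30 nM and 400 nM.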

Compound 4, half-maximal inhibitory concentration: 15 nM
For compound 4 the middle estimate is 6.7-fold (0.82 log units) above the measured one; measured number outside the range, below it.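

In this assay, putting methoxy in place of bromo brought a 13-fold lower number from compound 3 to compound 4 (1.12 log units; beyond the scatter), and this step can be set directly beside the earlier one on the core of compound 2: the same change on two cores in this assay, a 10-fold lower number (1.00 log units; beyond the scatter) from compound 2 to compound 1 and a 13-fold lower number (1.12 log units; beyond the scatter) from compound 3 to compound 4, 1.3-fold (0.12 log units) apart, within the scatter of two such steps. In these two pairs, then, the change gave a step of about the same size, even though the bromo that leaves sits on a different part of the molecule in each pair and the two cores are not the same. Within the data shown here, this is agreement between only two pairs in one cell assay, so it does not establish a rule for other cores or other assays, and it does not explain why the change lowers the number.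

The compounds shown leave open how other groups would behave at the place held by bromo and methoxy in compound 3 and compound 4, for instance ethoxy, an amine or a plain hydrogen, and whether such groups would also follow the same step on both cores. They also leave open whether the carboxylic acid shared by compound 3 and compound 4 could give way to an ester or an amide while the low numbers remain.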